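Ring-carbon isopropyl on the isopropyl-ester series

The source may hold more compounds than are shown below. What is called first, only, known or untested is meant among the compounds shown, and "the series" means these compounds.

Compound 3 `CC1=C(C(=O)OC(C)C)C(c2cccc([N+](=O)[O-])c2)N(C(=O)OC(C)C)C(=O)N1` gives 660 nM in an assay on HEK293 cells for antagonist activity at Voltage-dependent L-type calcium channel subunit alpha-1D (Rattus norvegicus), read by FLIPR; a lower number here means a stronger inhibitor, a higher number a weaker inhibitor. Among the three measured numbers this is the lowest, though compound 1 `CC1=C(C(=O)OC(C)C)C(c2cccc([N+](=O)[O-])c2)N(C(=O)C(C)C)C(=O)N1` with 990 nM sits within the scatter of it, the step of a 1.5-fold lower number from compound 1 to compound 3 (0.18 log units; within the scatter) being too small to read. Compound 2 `COC(=O)C1=C(C(C)C)NC(=O)N(C(=O)OC(C)C)C1c1cccc([N+](=O)[O-])c1` is far apart, at 10100 nM in this assay.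

Compound 4 `CC(C)OC(=O)C1=C(C(C)C)NC(=O)N(C(=O)OC(C)C)C1c1cccc([N+](=O)[O-])c1` has not been measured. It differs from compound 3 in one place: isopropyl in place of methyl on a double-bonded ring carbon.

For the measured compounds named here, no measured step in this set changes that ring carbon alone. Going by the values given here, the one step on record, from compound 1 to compound 3, concerns the group on the carbonyl carbon of the ring-nitrogen substituent and does not bear on the ring-carbon change. Among the compounds with values here, compound 2 is the only measured compound that already carries the isopropyl at this ring carbon, and it also carries a methyl ester instead of the isopropyl ester of compound 3 and compound 4; its number in this assay is much higher than that of compound 3. Within the data shown here, with no single-change step to lean on, the expectation is taken from that comparison: compound 4 is estimated at 4000 nM in this assay, within 1200 nM to 13000 nM, an expected step of a 6.1-fold higher number from compound 3 to compound 4 (0.78 log units; beyond the scatter) toward a weaker inhibitor.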

Compound 4, half-maximal inhibitory concentration: 4310 nM
Compound 4: middle estimate off by 1.1-fold (0.03 log units), on the low side; low and high end bracket the measured number.
By their numbers in this assay, from the lowest: compounds 3 and 1 (each within the scatter of the next); then compound 4; then compound 2.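

Isopropyl in place of methyl on the double-bonded ring carbon can now be read as a single change in this assay: a 6.5-fold higher number from compound 3 to compound 4 (0.81 log units; beyond the scatter), toward a weaker inhibitor, with the isopropoxycarbonyl group on the neighbouring ring atom and the rest of the core held constant. With the isopropyl kept at that ring carbon, isopropyl in place of methyl on an oxygen next to a carbonyl group gives a 2.3-fold lower number from compound 2 to compound 4 (0.37 log units; beyond the scatter), so the ester change also has its own step and moves the number in the stronger direction on this background. The compounds shown carry no measurement that accounts for either step.

Going by these compounds, at this ring carbon the series shows only methyl and isopropyl, so the trend across sizes stays open, and an ethyl, a cyclopropyl or a hydrogen there would be needed to tell whether the number rises gradually or abruptly. Also open, on these data alone, is whether the ring-carbon step keeps its size when the ring-nitrogen substituent carries the isopropyl on its carbonyl carbon, as in compound 1, rather than the isopropoxy of compound 3.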